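The source may hold more compounds than are shown below. What is called first, only, known or untested is meant among the compounds shown, and "the series" means these compounds.

Measured compounds:

Compound 1, `O=C(Nc1cccc(-n2cc(-c3ccncc3)c(-c3cc(O)cc(Cl)c3)n2)c1)Nc1ccc(Cl)c(C(F)(F)F)c1`: in a functional assay on SNB-19 cells (Homo sapiens) for inhibition, read by sulforhodamine B assay, with a stated time of 48 h, tested at 100 uM (on this read-out higher numbers stand for a weaker effect at the one concentration tested and lower numbers for a stronger effect), compound 1 gives -33%.
Compound 2, `O=C(Nc1cccc(-n2cc(-c3ccncc3)c(-c3cc(O)cc(Cl)c3)n2)c1)Nc1ccc(Cl)c(Cl)c1`: in this assay compound 2 gives -26%.
Compound 3, `COc1cc(Cl)cc(-c2nn(-c3cccc(NC(=O)Nc4cc(C(F)(F)F)cc(C(F)(F)F)c4)c3)cc2-c2ccncc2)c1`: in this assay compound 3 gives -42%.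

Compound 3 stands lowest of the three numbers. Its nearest neighbour is compound 1, and the gap between them lies within the scatter, so the two cannot be ranked against each other; compound 2 lies furthest away, and that gap is beyond the scatter.

Compound 4, `COc1cc(Cl)cc(-c2nn(-c3cccc(NC(=O)Nc4cccc(C(F)(F)F)c4)c3)cc2-c2ccncc2)c1`, differs from compound 3 in one place: hydrogen in place of trifluoromethyl on an aromatic carbon.

For the measured compounds named here, only one measured step touches the same region of the molecule. a number 7 percentage points higher from compound 1 to compound 2 (within the scatter) exchanged a trifluoromethyl for a chloro on the urea-bearing aryl ring and stayed within the scatter. Going by the values given here, no measured pair removes a trifluoromethyl outright and leaves hydrogen, so the present change has no direct precedent. Given that the one comparable replacement moved little, the step is expected to be small, at most a modest shift toward a weaker effect: a number 12 percentage points higher from compound 3 to compound 4 (beyond the scatter).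

For compound 4 in this assay the estimate is -30%, with a range from -50% to -10%.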

Compound 4, a percentage reported as activity, at one concentration (the size of the read-out at that concentration, not a potency): -13%
For compound 4 the middle estimate is 17 percentage points below the measured one; the measured number falls inside the stated range.
By their numbers in this assay, from the lowest: compounds 3, 1 and 2 (each within the scatter of the next, the first and the last beyond it); then compound 4.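

In this assay, the step of a number 29 percentage points higher from compound 3 to compound 4 (beyond the scatter) lies beyond the scatter, and it shows that the trifluoromethyl on this aromatic carbon of a six-membered aromatic ring of carbon only, meta to a trifluoromethyl group, cannot be exchanged for hydrogen without a clear shift toward a weaker effect at the one concentration tested. The earlier step, a number 7 percentage points higher from compound 1 to compound 2 (within the scatter), had only put one group in place of another on a different pair and stayed within the scatter, whereas this change leaves hydrogen with no group in its place and shows that this loss does register in the read-out. No experimental information shown here accounts for the size of this shift.

The compounds shown leave open whether a nitrile, a fluoro or an amine on this same carbon would give a number closer to that of compound 3 at -42% or to that of compound 4 at -13%. Going by these compounds, it also remains open whether the same exchange of trifluoromethyl for hydrogen would give a step of similar size on the core of compound 1, which carries a hydroxyl.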